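The compounds below may be only part of what the source reports. "The series", "measured", "known", "first", "only" and "open" are said of these compounds alone.

Measured in a functional assay for agonist activity at Bile acid receptor (Homo sapiens), read by a luciferase reporter; a higher number here means that more compound is needed for the effect, a lower number that less compound is needed:
compound 1 `O=C(O)c1ccccc1NC(=O)C(C1CCCCC1)n1c(-c2ccc(Cl)cc2)nc2cc(F)c(F)cc21`, which gives only a limit of this assay, > 40000 nM.
compound 2 `O=C(O)Cc1ccc(NC(=O)C(C2CCCCC2)n2c(-c3ccc(Cl)cc3)nc3cc(F)c(F)cc32)cc1`, which gives 4900 nM.
compound 3 `Cc1nc(NC(=O)C(C2CCCCC2)n2c(-c3ccc(Cl)cc3)nc3cc(F)c(F)cc32)sc1C(=O)O`, which gives 10400 nM.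

Of the two numbers shown, compound 3 carries the highest, with compound 2 the nearest, as a 2.1-fold higher number from compound 2 to compound 3 (0.33 log units; beyond the scatter) tells. The value of compound 1 is a limit and not a number (the limit of > 40000 nM in this assay, at which 1 of the 3 values shown sits). Compound 4 `O=C(O)c1ccc(NC(=O)C(C2CCCCC2)n2c(-c3ccc(Cl)cc3)nc3cc(F)c(F)cc32)nc1` has not yet been measured. It differs from compound 3 by 5-carboxypyridin-2-yl in place of 5-carboxy-4-methyl-1,3-thiazol-2-yl on an amide-type nitrogen. Going by the values given here, no measured step swaps exactly these two groups, but every measured step concerns the same place on the amide-type nitrogen: an at least 8.1-fold lower number from compound 1 to compound 2 (0.91 log units; beyond the scatter) and an at least 3.8-fold lower number from compound 1 to compound 3 (0.58 log units; beyond the scatter) were each at least modest, and a 2.1-fold higher number from compound 2 to compound 3 (0.33 log units; beyond the scatter) was modest. Since the group entering compound 4 again holds one six-membered aromatic ring, as the group in compound 2 did, and a 2.1-fold higher number from compound 2 to compound 3 (0.33 log units; beyond the scatter) was modest, the step of a 1.7-fold lower number from compound 3 to compound 4 (0.24 log units; within the scatter) in this assay is expected to be modest and toward a lower number. Compound 4 is estimated at 6000 nM, with a range from 2000 nM to 25000 nM.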

Compound 4, half-maximal effective concentration: 10600 nM
Compound 4: the middle estimate sits 1.8-fold (0.25 log units) below what was measured; the measured number falls inside the stated range.
By their numbers in this assay, from the lowest: compound 2; then compounds 3 and 4 (each within the scatter of the next). At a limit, above all of these: compound 1.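

In this assay, the five-membered 5-carboxy-4-methyl-1,3-thiazol-2-yl and the six-membered 5-carboxypyridin-2-yl stand level on the amide-type nitrogen, as a 1.0-fold higher number from compound 3 to compound 4 (0.01 log units; within the scatter) shows, so here the ring type does not separate the two compounds. A single six-membered aromatic ring does not by itself match the 4-(carboxymethyl)phenyl group, as a 2.2-fold higher number from compound 2 to compound 4 (0.34 log units; beyond the scatter) shows, and compound 2 keeps the lowest number of the set. The comparison with compound 1, an at least 3.7-fold lower number from compound 1 to compound 4 (0.57 log units; beyond the scatter), rests on a limit and not a number: the limit of > 40000 nM in this assay, at which 1 of the 4 values shown sits.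

The compounds shown do not tell whether the edge of compound 2 lies in its carboxymethyl chain or in its ring, which carries no ring nitrogen; a 4-carboxyphenyl group would help to separate the two. Whether the carboxylic acid itself is needed also stays open, as every compound shown carries one and none carries a primary amide or a tetrazole instead.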